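Head-group swap from compound 1 to compound 4

The source may report more compounds than this note shows. Statements on the series, on what has been measured and on what is new or still open speak of the compounds shown alone.

Compound 1 `COc1cc2ncnc(Nc3ccc(Cl)c(C(F)(F)F)c3)c2cc1OCCCCC(=O)Nc1ccc(S(N)(=O)=O)cc1` gives 3910 nM in a functional assay on A-431 cells (Homo sapiens) for antiproliferative activity, read by MTT assay, with a stated time of 72 h (a lower number here means a stronger inhibitor, a higher number a weaker inhibitor), the lowest of the three measured numbers; compound 3 `COc1cc2ncnc(Nc3ccc(Cl)cc3)c2cc1OCCCCC(=O)Nc1ccc(S(N)(=O)=O)cc1` is nearest with 7120 nM, and compound 2 `C#Cc1cccc(Nc2ncnc3cc(OC)c(OCCCCC(=O)Nc4ccc(S(N)(=O)=O)cc4)cc23)c1` is furthest with 17700 nM. Compound 4 `COc1cc2ncnc(Nc3cccc(C)c3)c2cc1OCCCCC(=O)Nc1ccc(S(N)(=O)=O)cc1` differs from compound 1 in one place: 3-methylphenyl in place of 4-chloro-3-(trifluoromethyl)phenyl on a nitrogen on an aromatic ring. Within the data shown here, two measured steps touch the same nitrogen. Dropping the trifluoromethyl gave a 1.8-fold higher number from compound 1 to compound 3 (0.26 log units; within the scatter), a step inside the scatter, while exchanging the whole head group for 3-ethynylphenyl gave a 4.5-fold higher number from compound 1 to compound 2 (0.66 log units; beyond the scatter), a step beyond it. Between the two alternatives the step was a 2.5-fold lower number from compound 2 to compound 3 (0.40 log units; beyond the scatter). Both head groups tried so far in place of that of compound 1 left the number no lower, and the larger change gave the larger step, so a modest rise in this assay is expected for compound 4, probably beyond the scatter. The expected step is a 3.6-fold higher number from compound 1 to compound 4 (0.55 log units; beyond the scatter). Compound 4 is estimated at 14000 nM, within a range from 5000 nM to 40000 nM.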

Compound 4, half-maximal inhibitory concentration: 7460 nM
The estimate for compound 4 lay 1.9-fold (0.27 log units) above the measured number; the range from low to high includes it.
By their numbers in this assay, from the lowest: compounds 1, 3 and 4 (each within the scatter of the next); then compound 2.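

In this assay, the 3-methylphenyl head group leaves compound 4 within the scatter of both chlorinated analogues (a 1.9-fold higher number from compound 1 to compound 4 (0.28 log units; within the scatter); a 1.0-fold higher number from compound 3 to compound 4 (0.02 log units; within the scatter)), so neither the chlorine nor the trifluoromethyl is needed to hold the number at this level. Among these compounds, the single change separating two head groups is methyl in place of ethynyl (a 2.4-fold lower number from compound 2 to compound 4 (0.38 log units; beyond the scatter)), and compound 2 is the only one of the four set apart beyond the scatter from all the others. No available data bear on why the ethynyl compound stands apart.

As far as these compounds go, whether an amine or a carboxylic acid in place of the methyl of compound 4 would move the number beyond the scatter remains open. So does the effect of a shorter or longer chain on the shared core.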